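Benzoyl for phenylsulfonyl on the cyano-bearing chain

The source may hold more compounds than are shown below. What is called first, only, known or untested is meant among the compounds shown, and "the series" means these compounds.

The series shares the core seen in compound 3 `N#C/C(=C\c1c(-c2ccccc2)[nH]c2ccccc12)S(=O)(=O)c1ccccc1`, which in a functional assay on M14 cells (Homo sapiens) for inhibition, read by sulforhodamine B assay, with a stated time of 48 h (a lower number here means a stronger inhibitor of growth, a higher number a weaker inhibitor of growth), gives 3800 nM. Compound 1 `CC(=O)/C(=C\c1c(-c2ccccc2)[nH]c2ccccc12)S(=O)(=O)c1ccccc1` gives 521 nM in this assay, and compound 2 `COc1ccc2[nH]c(-c3ccccc3)c(/C=C(\C#N)S(=O)(=O)c3ccccc3)c2c1` gives 3700 nM. Compound 3 sits at the high end of the three numbers, but only its distance from compound 1 is meaningful: the step of a 7.3-fold higher number from compound 1 to compound 3 (0.86 log units; beyond the scatter) lies beyond the scatter, whereas a 1.0-fold higher number from compound 2 to compound 3 (0.01 log units; within the scatter) does not. Compound 4 `N#C/C(=C\c1c(-c2ccccc2)[nH]c2ccccc12)C(=O)c1ccccc1` differs from compound 3 by benzoyl in place of phenylsulfonyl on a double-bonded chain carbon bound to a double-bonded chain carbon and a triple-bonded carbon. Within the data shown here, no measured step touches this group directly. Among the measured compounds shown here, the one step on the chain, a 7.3-fold higher number from compound 1 to compound 3 (0.86 log units; beyond the scatter), exchanged the group on the other chain carbon and gave a modest move, and the ring change a 1.0-fold higher number from compound 2 to compound 3 (0.01 log units; within the scatter) stayed within the scatter. The expectation for compound 4 is therefore a step of a 1.3-fold lower number from compound 3 to compound 4 (0.10 log units; within the scatter) in this assay of modest size at most and of uncertain direction. Compound 4 is estimated at 3000 nM, with a range from 800 nM to 12000 nM.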

Compound 4, concentration for 50% growth inhibition: 4800 nM
For compound 4 the middle estimate is 1.6-fold (0.20 log units) below the measured one; measured number inside the range.
By their numbers in this assay, from the lowest: compound 1; then compounds 2, 3 and 4 (each within the scatter of the next).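

In this assay, benzoyl in place of phenylsulfonyl gives a 1.3-fold higher number from compound 3 to compound 4 (0.10 log units; within the scatter), so on this nitrile-bearing chain the sulfonyl sulfur is not required to keep the number within the scatter of compound 3. The earlier compounds shown here showed a step beyond the scatter only for the group on the other chain carbon, a 7.3-fold higher number from compound 1 to compound 3 (0.86 log units; beyond the scatter), while this position had not been examined. No measurement available here accounts for the two groups reading alike.

The compounds shown pair benzoyl only with nitrile, so it remains open whether the same exchange would also stay within the scatter with acetyl on the chain. Also open, as far as these compounds go, is how a group of another kind at this place, such as a carboxylic acid or a primary amide, would read.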